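The compounds below may be only part of what the source reports. "The series", "measured", "known", "first", "only" and "open" are said of these compounds alone.

So far, three compounds have been measured in an ADME assay on a cell-free system (plasma, Mus musculus); a higher number here means a larger unbound share of the compound, a lower number a smaller unbound share. Compound 1 `CN(C)S(=O)(=O)c1ccc(F)c(C#Cc2cc(Cl)ccc2OCC(=O)O)c1` gives 0.029 and compound 2 `CCCS(=O)(=O)c1ccc(F)c(C#Cc2cc(Cl)ccc2OCC(=O)O)c1` gives 0.007 in this test. Compound 3 `CC(C)c1ccc(S(C)(=O)=O)cc1C#Cc1cc(Cl)ccc1OCC(=O)O` gives 0.013 here, a number within the scatter of compound 2 and beyond the scatter below compound 1.

Compound 4 `CS(=O)(=O)c1ccc(F)c(C#Cc2cc(Cl)ccc2OCC(=O)O)c1` differs from compound 3 by one change, (fluoro in place of isopropyl on an aromatic carbon), which is fluoro in place of isopropyl on an aromatic carbon, ortho to a large group and para to a methylsulfonyl group. Among the compounds with values here, no measured step covers this exchange. The only one available, a 4.1-fold lower number from compound 1 to compound 2 (0.62 log units; beyond the scatter), concerns the group on the sulfonyl sulfur, so it bears on the change only indirectly, by showing that compounds carrying the fluoro can differ beyond the scatter.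

Compound 4 keeps the methylsulfonyl group of compound 3 and takes the fluoro of compound 1 and compound 2. A modest rise in this assay is therefore expected, and the estimated step is a 2.3-fold higher number from compound 3 to compound 4 (0.36 log units; beyond the scatter) in size. For compound 4 the estimated unbound fraction is 0.03, with an expected range of 0.014 to 0.065 in repeated measurements.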

Compound 4, unbound fraction: 0.054
Estimate against measurement, compound 4: 1.8-fold (0.26 log units) below; the measured number falls inside the stated range.
By their numbers in this assay, from the lowest: compounds 2 and 3 (each within the scatter of the next); then compounds 1 and 4 (each within the scatter of the next).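

In this assay, within the data shown here, fluoro in place of isopropyl on this aromatic carbon, para to a methylsulfonyl group, gives a 4.2-fold higher number from compound 3 to compound 4 (0.62 log units; beyond the scatter) as a direct reading of this exchange, which no earlier step supplied. With the fluoro kept, the group on the sulfonyl sulfur also matters: hydrogen in place of ethyl on the chain carbon bound to that sulfur gives a 7.7-fold higher number from compound 2 to compound 4 (0.89 log units; beyond the scatter) while methyl in place of dimethylamino gives a 1.9-fold higher number from compound 1 to compound 4 (0.27 log units; within the scatter) so methyl and dimethylamino cannot be told apart here. Nothing available accounts for any of these steps.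

The compounds shown leave open how a chloro or a methoxy group on this aromatic carbon would compare with fluoro and isopropyl. They also leave open whether the exchange keeps its size when propyl or dimethylamino stands on the sulfonyl sulfur.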